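Thiosemicarbazone series: arylidene ring substituent change

The compounds below may be only part of what the source reports. "The series", "measured", "known", "first", "only" and "open" are said of these compounds alone.

Measured so far:
compound 1, `CC1=CC[C@@H]([C@@](C)(O)CCCC(C)(C)NC(=S)NN)CC1`: 49400 nM in a functional assay on HT-29 cells (Homo sapiens) for cytotoxicity, read by sulforhodamine B assay; a higher number here means a weaker inhibitor of growth, a lower number a stronger inhibitor of growth
compound 2, `CC1=CC[C@@H]([C@@](C)(O)CCCC(C)(C)NC(=S)N/N=C\c2ccc(C)cc2)CC1`: 10400 nM

Compound 2 holds the lower of the two numbers in this assay. Among the measured compounds shown here, the only measured step, a 4.8-fold lower number from compound 1 to compound 2 (0.68 log units; beyond the scatter), concerns a group entering on the amide-type nitrogen and does not touch the aromatic ring.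

Compound 3, `CC1=CC[C@@H]([C@@](C)(O)CCCC(C)(C)NC(=S)N/N=C\c2ccc(N(C)C)cc2)CC1`, differs from compound 2 by dimethylamino in place of methyl on an aromatic carbon. For the measured compounds named here, no measured step bears on a change at this place, so the expectation rests on compound 2 alone. For compound 3 the expected step is a 1.3-fold lower number from compound 2 to compound 3 (0.11 log units; within the scatter), within the scatter. Compound 3 is estimated at 8000 nM, between 3000 nM and 25000 nM.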

Compound 3, concentration for 50% growth inhibition: 27700 nM
For compound 3 the middle estimate is 3.5-fold (0.54 log units) below the measured one; measured number outside the range, above it.
By their numbers in this assay, from the lowest: compound 2; then compounds 3 and 1 (each within the scatter of the next).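

On the aromatic carbon para to a large group, this assay responds to the substituent: dimethylamino in place of methyl gives a 2.7-fold higher number from compound 2 to compound 3 (0.43 log units; beyond the scatter) and leaves the lower number of this pair with the 4-methylphenyl compound. The earlier step on the amide-type nitrogen could not show that this ring position affects the read-out. Nothing at hand accounts for the shift.

Open, on these data alone, is how a hydrogen, a methoxy group or a chlorine atom at this carbon would compare with methyl and dimethylamino.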